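A few compounds are considered here, and "the series" means these few. Any claim that something is new, unique, unknown or untested is made for them only; others in the source may bear on it.

Of the compounds shown here, three of one series have been measured and a fourth awaits its number. Compound 2 `O=C(/C(=C\c1ccc(Br)cc1)Sc1ccc(Br)cc1)c1ccc(Br)cc1` carries bromo on all three outer rings, compound 1 `COc1ccc(/C=C(/Sc2ccc(Br)cc2)C(=O)c2ccc(Br)cc2)cc1` is its methoxy analogue, compound 3 `O=C(/C(=C\c1ccc(Br)cc1)S(=O)(=O)c1ccc(Br)cc1)c1ccc(Br)cc1` is the oxidised counterpart of compound 2, and compound 4 `COc1ccc(S(=O)(=O)/C(=C/c2ccc(Br)cc2)C(=O)c2ccc(Br)cc2)cc1` is the oxidised counterpart of compound 1.

In a functional assay on DU-145 cells (Homo sapiens) for inhibition, read by trypan blue exclusion, with a stated time of 96 h (a higher number here means a weaker inhibitor of growth, a lower number a stronger inhibitor of growth), compound 2 gives 1000 nM, compound 1 gives 25000 nM and compound 3 gives 10000 nM. Compound 1 differs from compound 2 by methoxy in place of bromo on an aromatic carbon, which produced a 25-fold higher number from compound 2 to compound 1 (1.40 log units; beyond the scatter). The difference between the core of compound 2 and the core of compound 3 is not broken down here; their two numbers show compound 3 as the weaker inhibitor of growth. Compound 4 differs from compound 3 by methoxy in place of bromo on an aromatic carbon, the same change as before, at the same place.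

In this assay a large upward step is expected, estimated as an 8.0-fold higher number from compound 3 to compound 4 (0.90 log units; beyond the scatter), an expectation resting on a 25-fold higher number from compound 2 to compound 1 (1.40 log units; beyond the scatter) seen for the first pair, though compound 3 alone shows how the oxidised core responds, so the size is uncertain. Compound 4 is therefore estimated at 80000 nM, within 20000 nM to 300000 nM.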

Compound 4, concentration for 50% growth inhibition: 6000 nM
For compound 4 the middle estimate is 13-fold (1.12 log units) above the measured one, outside the stated range (below it).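

In this assay, replacing 4-bromophenyl with 4-methoxyphenyl on the oxidised core gives a 1.7-fold lower number from compound 3 to compound 4 (0.22 log units; within the scatter), so compound 3 and compound 4 cannot be told apart. The change therefore does not carry over in size from the earlier pair to this one: the same change on two cores in this assay, a 25-fold higher number (1.40 log units; beyond the scatter) from compound 2 to compound 1 and a 1.7-fold lower number (0.22 log units; within the scatter) from compound 3 to compound 4, 42-fold (1.62 log units) apart, beyond the scatter of two such steps

This shows that the step seen for the first pair cannot be assumed for the second, but it does not show that the core alone sets the difference: contrary to the earlier description of the change as being at the same place, the structures put the methoxy of compound 4 on a different outer ring from that of compound 1. Among the compounds shown here, with only two pairs, no rule for other cores follows, and the reason for the gap remains unknown.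

The compounds shown leave open how the methoxy change behaves on each outer ring of a single core. They also leave open whether other replacements for bromo, such as an amine or a carboxylic acid, would respond differently on the two cores.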